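Notes on extending the ester chain of compound 2

The compounds below may be only part of what the source reports. "The series", "measured", "known", "first", "only" and "open" are said of these compounds alone.

- compound 1 `CCCCCCCCCCC(=O)OCCc1ccc(OCc2ccc(OC)cc2)c(OCc2ccc(OC)cc2)c1`: > 50000 nM
- compound 2 `CCCCCCCCCCCCCC(=O)OCCc1ccc(O)c(O)c1`: > 50000 nM
- compound 3 `CCCCCC(=O)OCCc1ccc(O)cc1`: 166000 nM

In a toxicity assay on MRC5 cells (Homo sapiens) for inhibition, read by MTT assay, with a stated time of 72 h (on this read-out lower numbers stand for stronger inhibition and higher numbers for weaker inhibition), compound 2 gives > 50000 nM, which is a limit and not a number. Compound 1 likewise gives only a limit, so compound 2 stands at the limit of > 50000 nM in this assay, at which 2 of the 3 values shown sit. Compound 3 gives a number, but no single change connects it with compound 2.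

Compound 4 `CCCCCCCCCCCCCCCC(=O)OCCc1ccc(O)c(O)c1` differs from compound 2 by ethyl in place of hydrogen on a saturated chain carbon, ten or more bonds along the chain from a carbonyl carbon.

No measured pair sizes this change, so no direction is favoured. In this assay the expected step that the limit leaves unreadable from compound 2 to compound 4 stays within the usual scatter. For compound 4 the estimated value is 70000 nM, with an expected range from 30000 nM to 200000 nM.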

Compound 4, half-maximal inhibitory concentration: > 50000 nM
Compound 4 ended at the assay's limit; the forecaster's own chance of this, stated with the estimate: 70%; the middle value does not contradict the limit.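

Compound 2 and compound 4 both stand at a limit, and no step between them can be read: the limit of > 50000 nM in this assay, at which 3 of the 4 values shown sit.

The compounds shown leave open whether any change to the ester chain of compound 2 gives a readable number in this assay.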